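Swapping fluoro for chloro on a short-lived compound

This account rests on a few compounds, and the source may have more. Where it says the series, first, only, none or still open, it means among the compounds named here.

Compound 1 `O=C(O)Cn1nc(Cc2nc3cc(Cl)c(OCC(F)F)cc3[nH]2)c2ccccc2c1=O` gives 0.3 h
Compound 2 `O=C(O)Cn1nc(Cc2nc3cc(F)c(OCC4CC4)cc3[nH]2)c2ccccc2c1=O` gives 0.4 h

In an ADME assay on the whole organism (Mus musculus, strain CD1) for metabolic stability, read by LC-MS, with a stated time of 24 h, at a dose of 1 mg/kg by the intravenous route (on this read-out lower numbers stand for a shorter-lived compound and higher numbers for a longer-lived compound), compound 2 stands at (0.4 h), within the usual scatter of compound 1 (0.3 h), so neither can be ranked above the other. Compound 3 `O=C(O)Cn1nc(Cc2nc3cc(Cl)c(OCC4CC4)cc3[nH]2)c2ccccc2c1=O` is not yet measured. It differs from compound 2 by chloro in place of fluoro on an aromatic carbon (chloro in place of fluoro on an aromatic carbon, ortho to a cyclopropylmethoxy group). Going by the values given here, no measured pair isolates this change. Compound 1 also carries chloro and still gives (0.3 h), so no change beyond the scatter is expected in this assay here. The expected step is no change at the digits printed from compound 2 to compound 3 (within the scatter) (an estimate, not a measurement). The estimate for compound 3 is 0.4 h (expected range 0.2 h to 0.8 h)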

Compound 3, half-life: 0.6 h
The estimate for compound 3 lay 1.5-fold (0.18 log units) below the measured number; measured number inside the range.
By their numbers in this assay, from the lowest: compounds 1, 2 and 3 (each within the scatter of the next).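

In this assay chloro in place of fluoro on an aromatic carbon, ortho to a cyclopropylmethoxy group, now has a measured pair, which shows a 1.5-fold higher number from compound 2 to compound 3 (0.18 log units; within the scatter) within the scatter. Cyclopropyl in place of difluoromethyl on a saturated chain carbon bound to an oxygen shows a 2.0-fold higher number from compound 1 to compound 3 (0.30 log units; within the scatter) and also lies within the scatter, so neither swap clearly separates these compounds. Nothing measured here offers a reason for either step. From the compounds shown here alone, whether a different group on that aromatic carbon, such as a nitrile or a methoxy group, would move the half-life beyond the scatter remains open.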